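A few compounds are considered here, and "the series" means these few. Any claim that something is new, unique, unknown or untested is made for them only; others in the source may bear on it.

Measured so far:
- compound 1 `CCCNC(=O)Nc1ccc(C(C)C)cc1`: 14000 nM
- compound 2 `CCC(C)c1ccc(NC(=O)NC)cc1`: 62000 nM

In a functional assay on L1210 cells (Mus musculus) (on this read-out lower numbers stand for stronger inhibition and higher numbers for weaker inhibition), compound 2 gives the higher of the two numbers at 62000 nM, and the gap down to compound 1 lies beyond the scatter. Compound 3 `CCCNC(=O)Nc1ccc(C(C)CC)cc1` differs from compound 2 by ethyl in place of hydrogen on a saturated chain carbon bound to an amide-type nitrogen, which also reads as methyl to propyl. Among the compounds with values here, no measured step isolates this change. Compound 1, which also carries propylamino, gives 14000 nM, so a decrease beyond the scatter is expected in this assay. The expected size is a 5.6-fold lower number from compound 2 to compound 3 (0.75 log units; beyond the scatter). For compound 3 the estimate is 11000 nM, with an expected range of 4000 nM to 30000 nM.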

Compound 3, half-maximal inhibitory concentration: 30000 nM
For compound 3 the middle estimate is 2.7-fold (0.44 log units) below the measured one; measured number inside the range.
By their numbers in this assay, from the lowest: compound 1; then compound 3; then compound 2.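

Methylamino to propylamino alone gives a 2.1-fold lower number from compound 2 to compound 3 (0.32 log units; beyond the scatter) in this assay and shows that this position affects the number on its own, though the step is modest. With propylamino held fixed, methyl in place of hydrogen on a saturated chain carbon, two bonds along the chain from an aromatic carbon, gives a 2.1-fold higher number from compound 1 to compound 3 (0.33 log units; beyond the scatter) and so moves the number the opposite way. No supporting data account for either step.

From the compounds shown here alone, whether butyl in place of propyl would lower the number further remains open. So does the effect of a hydroxyl group on the propyl chain.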